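Pyridin-4-yl in place of 1,3-benzothiazol-2-yl

The source may report more compounds than this note shows. Statements on the series, on what has been measured and on what is new or still open speak of the compounds shown alone.

Compound 1 `CC1=C(CC(=O)NCCN(C)C)c2cc(F)ccc2/C1=C\c1nc2ccccc2s1` gives 1570 nM
Compound 2 `CC1=C(CC(=O)N(C)CCN(C)C)c2cc(F)ccc2/C1=C\c1nc2ccccc2s1` gives 2020 nM

Both were measured in a functional assay on HT-29 cells (Homo sapiens) for inhibition, read by CellTiter-Glo, with a stated time of 72 h (a lower number here means that less compound is tolerated, a higher number that more compound is tolerated), and compound 1 stands level with compound 2, within the scatter. Compound 3 `CC1=C(CC(=O)NCCN(C)C)c2cc(F)ccc2/C1=C\c1ccncc1` puts pyridin-4-yl in place of 1,3-benzothiazol-2-yl on a double-bonded chain carbon bound to a double-bonded ring carbon. Within the data shown here, the one measured step of a 1.3-fold higher number from compound 1 to compound 2 (0.11 log units; within the scatter) comes from methyl in place of hydrogen on an amide-type nitrogen, a different place, so it offers no direct guide here. In this assay the expected step is a 3.8-fold higher number from compound 1 to compound 3 (0.58 log units; beyond the scatter) as a tentative estimate toward a higher number. For compound 3 the estimated value is 6000 nM with an expected range from 2000 nM to 20000 nM in this measurement.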

Compound 3, half-maximal cytotoxic concentration: 6890 nM
The estimate for compound 3 lay 1.1-fold (0.06 log units) below the measured number; the range from low to high includes it.
By their numbers in this assay, from the lowest: compounds 1 and 2 (each within the scatter of the next); then compound 3.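

The amide methyl change stayed within the scatter, but this change at the double-bonded chain carbon does not: in this assay, pyridin-4-yl in place of 1,3-benzothiazol-2-yl gives a 4.4-fold higher number from compound 1 to compound 3 (0.64 log units; beyond the scatter). The number at this position therefore depends on the ring group it carries, and here the group with fewer heavy atoms allows more compound to be tolerated. Nothing measured here explains this rise. On these data alone, it remains open whether the step follows the loss of one ring or the change in ring atoms. A phenyl group at the same place would help separate these two.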